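Phenyl for 4-chlorobenzyl on the amine nitrogen

The compounds below may be only part of what the source reports. "The series", "measured", "known", "first", "only" and "open" are said of these compounds alone.

In a functional assay on MCF7 cells (Homo sapiens) for inhibition (on this read-out lower numbers stand for stronger inhibition and higher numbers for weaker inhibition), compound 2 `O=C(NO)c1ccc(-c2ccc(CNCc3ccc(Cl)cc3)cn2)s1` gives 130 nM, and compound 1 `O=C(NO)c1ccc(-c2ccc(CNCc3ccccc3Cl)cn2)s1` gives 110 nM. Within the data shown here, these two values lie within the scatter of each other, so compound 2 stands level with the only other measured member of the series.

The next structure, compound 3 `O=C(NO)c1ccc(-c2ccc(CNc3ccccc3)cn2)s1`, keeps the shared core and changes the group on the amine: phenyl in place of 4-chlorobenzyl on an amine nitrogen.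

Among the measured compounds shown here, only one measured step bears on this change, and only loosely. It is a 1.2-fold higher number from compound 1 to compound 2 (0.07 log units; within the scatter), which swaps 2-chlorophenyl for 4-chlorophenyl and stays within the scatter. For the measured compounds named here, no measured compound lacks the chlorine, and none carries phenyl on the amine nitrogen, so the size of this change is untested. A moderate shift towards weaker inhibition in this assay is a cautious working assumption, not a measured trend, and the range is kept wide. The expected step is a 1.5-fold higher number from compound 2 to compound 3 (0.19 log units; within the scatter). For compound 3 the estimated value is 200 nM, with an expected range of 70 nM to 600 nM.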

Compound 3, half-maximal inhibitory concentration: 370 nM
Beside the measured number, compound 3's estimate is 1.9-fold (0.27 log units) below it; measured number inside the range.
By their numbers in this assay, from the lowest: compounds 1 and 2 (each within the scatter of the next); then compound 3.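

In this assay, phenyl in place of 4-chlorobenzyl on the amine nitrogen gives a 2.8-fold higher number from compound 2 to compound 3 (0.45 log units; beyond the scatter), and phenyl in place of 2-chlorobenzyl gives a 3.4-fold higher number from compound 1 to compound 3 (0.53 log units; beyond the scatter), so inhibition at this position responds to the group on the nitrogen in a way the earlier swap of 2-chlorophenyl for 4-chlorophenyl did not show. Both steps are modest but beyond the scatter, and both run towards weaker inhibition; the change also removes the chlorine and the saturated chain carbon together, so the loss cannot be assigned to either one alone. No measurement shown here explains the loss.

The compounds shown leave open whether unsubstituted benzyl on the amine nitrogen would stand with compound 1 and compound 2 or with compound 3, and whether 4-chlorophenyl on that nitrogen would do the same, two comparisons that would separate the part played by the chlorine from that of the saturated chain carbon. From the compounds shown here alone, how a longer chain, such as 2-phenylethyl, would behave on the same nitrogen also remains open.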